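Aryl swaps on the allyl series: compound 3 to compound 4

A few compounds are considered here, and "the series" means these few. Any claim that something is new, unique, unknown or untested is made for them only; others in the source may bear on it.

Measured so far in a functional assay on U-937 cells (Homo sapiens) for cytotoxicity, read by CCK-8 assay, with a stated time of 72 h; on this read-out higher numbers stand for weaker inhibition and lower numbers for stronger inhibition:
compound 1 `C=CCn1c(=O)/c(=C\c2ccccc2Cl)[nH]c(=O)/c1=C\c1ccccc1OC` gives 700 nM
compound 2 `C=CCn1c(=O)/c(=C\c2ccccc2C(F)(F)F)[nH]c(=O)/c1=C\c1ccccc1OC` gives 1500 nM
compound 3 `C=CCn1c(=O)/c(=C\c2cc(F)ccc2C)[nH]c(=O)/c1=C\c1ccccc1OC` gives 1000 nM

Compound 3 holds the second highest of the three numbers in this assay. Its nearest neighbour is reached by a 1.4-fold higher number from compound 1 to compound 3 (0.15 log units; within the scatter), its furthest by a 1.5-fold lower number from compound 2 to compound 3 (0.18 log units; within the scatter); both lie within the scatter. Going by the values given here, the only step beyond the scatter is a 2.1-fold higher number from compound 1 to compound 2 (0.33 log units; beyond the scatter), a modest one.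

Compound 4 `C=CCn1c(=O)/c(=C\c2cccc(C)c2)[nH]c(=O)/c1=C\c1ccccc1OC` differs from compound 3 by 3-methylphenyl in place of 5-fluoro-2-methylphenyl on a double-bonded chain carbon bound to an aromatic carbon. Both earlier swaps of the whole aryl group at this place stayed within the scatter, so for compound 4 the expected step in this assay is no change at the digits printed from compound 3 to compound 4 (within the scatter), none beyond the scatter in either direction. Compound 4 is therefore estimated at 1000 nM, with a range of 400 nM to 2500 nM.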

Compound 4, half-maximal inhibitory concentration: 5100 nM
Compound 4: the middle estimate sits 5.1-fold (0.71 log units) below what was measured; the measured number lies above the stated range.
By their numbers in this assay, from the lowest: compounds 1, 3 and 2 (each within the scatter of the next, the first and the last beyond it); then compound 4.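

In this assay, going by these compounds alone, this place proves sensitive to the choice of aryl group: a 5.1-fold higher number from compound 3 to compound 4 (0.71 log units; beyond the scatter) and a 3.4-fold higher number from compound 2 to compound 4 (0.53 log units; beyond the scatter) and a 7.3-fold higher number from compound 1 to compound 4 (0.86 log units; beyond the scatter) are each larger than any step among the earlier compounds. Compound 4 is the only one of the four whose aryl group here carries no halogen, yet this single swap cannot separate the lost fluorine from the changed methyl placement. No supporting data explain the weaker inhibition.

From the compounds shown here alone, whether 2-methylphenyl or 3-fluorophenyl would give a number nearer that of compound 3 remains open. Going by these compounds, the effect of an amine or a carboxylic acid on this aryl ring is also open.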